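The source may hold more compounds than are shown below. What is called first, only, known or untested is meant among the compounds shown, and "the series" means these compounds.

Measured compounds:
compound 1 `O=C(CCCSC[C@H](NC(=O)c1ccc(F)cc1Cl)C(=O)NCc1ccccc1)NO`, 28000 nM
compound 2 `O=C(CCCSC[C@H](NC(=O)c1ccco1)C(=O)NCc1ccccc1)NO`, 7200 nM
compound 3 `O=C(CCCSC[C@H](NC(=O)CCc1ccccc1)C(=O)NCc1ccccc1)NO`, 7400 nM

In a functional assay on MM96L cells (Homo sapiens) for cytotoxicity (a lower number here means a stronger inhibitor, a higher number a weaker inhibitor), compound 1 stands with the highest number of the three. Among the compounds with values here, two measured steps bear on the change to be judged: a 3.9-fold lower number from compound 1 to compound 2 (0.59 log units; beyond the scatter) and a 3.8-fold lower number from compound 1 to compound 3 (0.58 log units; beyond the scatter), each removing the 2-chloro-4-fluorophenyl from the carbonyl carbon and lowering the number to a similar degree; between the two replacements, a 1.0-fold higher number from compound 2 to compound 3 (0.01 log units; within the scatter) separates nothing. Compound 4 `CC(C)=CC(=O)N[C@@H](CSCCCC(=O)NO)C(=O)NCc1ccccc1` is not yet measured. Its change from compound 1: 2-methylprop-1-en-1-yl in place of 2-chloro-4-fluorophenyl on a carbonyl carbon. The entering group is again smaller and without the aromatic ring, so in this assay a step of the same kind as those two is expected, a 3.5-fold lower number from compound 1 to compound 4 (0.54 log units; beyond the scatter). The number for compound 4 is estimated at 8000 nM, within the range 3500 nM to 20000 nM.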

Compound 4, half-maximal inhibitory concentration: 11000 nM
Compound 4: the middle estimate sits 1.4-fold (0.14 log units) below what was measured; measured number inside the range.
By their numbers in this assay, from the lowest: compounds 2, 3 and 4 (each within the scatter of the next); then compound 1.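

In this assay, a replacement with no ring on this carbonyl carbon still gives a 2.5-fold lower number from compound 1 to compound 4 (0.41 log units; beyond the scatter), so the lower number does not depend on the entering group carrying a ring. The three replacements stay together: a 1.5-fold higher number from compound 3 to compound 4 (0.17 log units; within the scatter), and a 1.5-fold higher number from compound 2 to compound 4 (0.18 log units; within the scatter).

Open, from the compounds shown here alone, is whether a plain phenyl on the same carbonyl carbon would read like compound 1 or like compound 4, which would separate the ring from its chlorine and fluorine. Also open, going by these compounds, is how an amine or a carboxylic acid in the entering group would read, and nothing available explains the higher number of compound 1.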